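This account rests on a few compounds, and the source may have more. Where it says the series, first, only, none or still open, it means among the compounds named here.

Compound 1, `CCCSc1nc(N/N=C(\C)c2ccc(OC)cc2)c2nnn(Cc3ccccc3)c2n1`: in a functional assay on MCF7 cells (Homo sapiens) for antiproliferative activity, read by MTT assay, with a stated time of 72 h (a lower number here means a stronger inhibitor, a higher number a weaker inhibitor), compound 1 gives > 64000 nM, which is a limit of the assay and not a number.
Compound 2, `CCCSc1nc(N/N=C(\C)c2ccccc2O)c2nnn(Cc3ccco3)c2n1`: in this assay compound 2 gives 29000 nM.
Compound 3, `C#CCSc1nc(N/N=C/c2cc(OC)c(OC)c(OC)c2)c2nnn(Cc3ccccc3)c2n1`: in this assay compound 3 gives 17000 nM.

Compound 1 therefore stands at the edge of what this assay reports, with no number of its own; all that can be said of it is the limit of > 64000 nM in this assay, at which 1 of the 3 values shown sits. Within the data shown here, compound 2 and compound 3 each return a number, but both differ from compound 1 in more than one place, so no single step between measured compounds can be drawn.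

Compound 4, `CCCSc1nc(N/N=C(\C)c2ccc(Br)cc2)c2nnn(Cc3ccccc3)c2n1`, differs from compound 1 in one place: bromo in place of methoxy on an aromatic carbon. Cut one bond further out, the change reads 4-methoxyphenyl to 4-bromophenyl. Among the measured compounds shown here, with no measured step of this kind to lean on, the expected change from compound 1 to compound 4 in this assay is modest, in either direction, and may not exceed the usual scatter. Because compound 1 gives only > 64000 nM, a move of that size could still leave compound 4 without a number. Compound 4 is estimated at 45000 nM, expected to fall between 15000 nM and 150000 nM, an expected step of an at least 1.4-fold lower number from compound 1 to compound 4 (0.15 log units; that floor lies within the scatter).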

Compound 4, half-maximal inhibitory concentration: 13000 nM
Beside the measured number, compound 4's estimate is 3.5-fold (0.54 log units) above it; the measured number lies below the stated range.
By their numbers in this assay, from the lowest: compounds 4, 3 and 2 (each within the scatter of the next, the first and the last beyond it). At a limit, above all of these: compound 1.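

Bromo in place of methoxy, on an aromatic carbon para to a large group, gives the first step between compounds that differ in one place, and in this assay it reads an at least 4.9-fold lower number from compound 1 to compound 4 (0.69 log units; beyond the scatter). This shows that the position is not indifferent: changing this one group is enough to take the series from a limit of the assay to a measured number. The step can be given only as a floor because compound 1 has a limit and not a number: the limit of > 64000 nM in this assay, at which 1 of the 4 values shown sits.

Whether the change owes more to the arrival of bromo or to the departure of methoxy stays open, with no third group at this position among the compounds shown. As far as these compounds go, how a chloro, a nitrile or an amine would read there is also open, as is whether bromo would give a similar step with a different chain on the sulfur.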